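A few compounds are considered here, and "the series" means these few. Any claim that something is new, unique, unknown or untested is made for them only; others in the source may bear on it.

Measured compounds:
compound 1 `COc1cc2c(Oc3ccc(NC(=O)c4nn(-c5ccccc5F)c(=O)c5ccccc45)cc3F)ccnc2cc1OCCCN1CCCC1` — 140 nM
compound 2 `COc1ccc(-n2nc(C(=O)Nc3ccc(Oc4ccnc5cc(OCCCN6CCCC6)c(OC)cc45)c(F)c3)c3ccccc3c2=O)cc1` — 1320 nM

In a functional assay on MKN-45 cells (Homo sapiens) for cytotoxicity, read by MTT assay, with a stated time of 72 h (on this read-out lower numbers stand for stronger inhibition and higher numbers for weaker inhibition), compound 1 gives 140 nM, the lowest of the two numbers. Compound 2 gives 1320 nM. Among the compounds with values here, the only measured step is a 9.4-fold higher number from compound 1 to compound 2 (0.97 log units; beyond the scatter), and it concerns the aryl group on the aromatic nitrogen of the shared core, not the amine at the end of the ether chain.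

Compound 3 `COc1cc2c(Oc3ccc(NC(=O)c4nn(-c5ccccc5F)c(=O)c5ccccc45)cc3F)ccnc2cc1OCCCN1CCN(C)CC1` keeps the 2-fluorophenyl and the rest of the core of compound 1 unchanged; the difference is 4-methylpiperazin-1-yl in place of pyrrolidin-1-yl on a saturated chain carbon, three bonds along the chain from an oxygen on an aromatic ring. Within the data shown here, no measured step touches this part of the molecule, so nothing in the data gives a direction or a size for the change at the chain end. Among the measured compounds shown here, the one step known, from the aryl change, does not transfer to this position. The working expectation is therefore a step that stays within the scatter, taking compound 1 as the reference. The step from compound 1 to compound 3 is expected to be no change at the digits printed from compound 1 to compound 3 (within the scatter). For compound 3 the estimate in this assay is 140 nM, with a range from 50 nM to 450 nM.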

Compound 3, half-maximal inhibitory concentration: 210 nM
For compound 3 the middle estimate is 1.5-fold (0.18 log units) below the measured one; low and high end bracket the measured number.
By their numbers in this assay, from the lowest: compounds 1 and 3 (each within the scatter of the next); then compound 2.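

In this assay, replacing pyrrolidin-1-yl with 4-methylpiperazin-1-yl at the end of the propyl chain gives a 1.5-fold higher number from compound 1 to compound 3 (0.18 log units; within the scatter). This position therefore takes a six-membered ring with a second ring nitrogen and a methyl group in place of the five-membered ring, with no difference that can be told from the scatter. Among these three compounds, the only step beyond the scatter remains the one at the aryl group on the aromatic nitrogen, a 9.4-fold higher number from compound 1 to compound 2 (0.97 log units; beyond the scatter), and no measurement of any property of the two chain-end groups is available to bear on the result.

On these data alone, whether the chain end stays this permissive with morpholin-4-yl, with an open-chain dimethylamino group, with a carboxylic acid, or with a shorter ethyl or longer butyl linker remains open. It is also open whether the same exchange gives a similar result when the 4-methoxyphenyl group of compound 2 replaces the 2-fluorophenyl group, as the pair shown here carries only the 2-fluorophenyl group.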